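Adding a methyl to the unsaturated lactone of compound 1

The source may report more compounds than this note shows. Statements on the series, on what has been measured and on what is new or still open speak of the compounds shown alone.

Within the data shown here, compound 1 `C=C/C=C\[C@H](C)[C@H](OC(N)=O)[C@@H](C)[C@H](O)[C@@H](C)C/C(C)=C\[C@H](C)[C@@H](O)[C@@H](C)/C=C\[C@@H](O)C[C@@H]1OC(=O)C=C[C@H]1C` is the stronger of the two compounds measured so far. In a functional assay on the whole organism (SK-OV-3 cells, Mus musculus) for inhibition, with SK-OV-3 (Homo sapiens) as the target (on this read-out higher numbers stand for weaker inhibition and lower numbers for stronger inhibition), compound 1 gives 3.4 nM, the lowest number seen. Among the measured compounds shown here, the only other measured compound, compound 2 `C=C/C=C\[C@H](C)[C@H](OC(N)=O)[C@@H](C)[C@H](O)[C@@H](C)C/C=C\[C@H](C)[C@@H](O)[C@@H](C)/C=C\[C@@H](O)C[C@@H]1OC(=O)[C@H](C)[C@@H](O)[C@H]1C`, gives 35 nM in this assay, a number that stands clearly beyond the scatter above that of compound 1; since compound 2 differs from compound 1 in more than one place, the two values say nothing on their own about any single change.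

Compound 3 `C=C/C=C\[C@H](C)[C@H](OC(N)=O)[C@@H](C)[C@H](O)[C@@H](C)C/C(C)=C\[C@H](C)[C@@H](O)[C@@H](C)/C=C\[C@@H](O)C[C@@H]1OC(=O)C(C)=C[C@H]1C` has not been measured yet. It differs from compound 1 in one place: methyl in place of hydrogen on a double-bonded ring carbon. For the measured compounds named here, no pair of measured compounds shows what this change does, so any expectation rests on the value of compound 1 alone. The step of a 1.8-fold higher number from compound 1 to compound 3 (0.25 log units; within the scatter) is estimated to be small, toward slightly weaker inhibition, and not clearly beyond the scatter. For compound 3 the expected value in this assay is 6 nM, with a range from 2 nM to 20 nM.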

Compound 3, half-maximal inhibitory concentration: 3.4 nM
For compound 3 the middle estimate is 1.8-fold (0.25 log units) above the measured one, and the stated range covers the measured number.
By their numbers in this assay, from the lowest: compounds 1 and 3 (each within the scatter of the next); then compound 2.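

In this assay, the step at this position reads no change at the digits printed from compound 1 to compound 3 (within the scatter), where methyl takes the place of hydrogen on a double-bonded ring carbon, two ring bonds from the ring oxygen. This is the first comparison among the compounds shown in which only one place differs, and it shows that this carbon of the six-membered ring can carry a methyl without any change in inhibition that stands out from the scatter of this read-out. Nothing available gives a measured reason for this result, so the step can be reported only as an observation.

The compounds shown cover only hydrogen and methyl at this carbon, so one methyl cannot show how much room for change the position has, and an ethyl group, a longer chain, a hydroxymethyl group, an amine or a carboxylic acid there could behave quite differently. On these data alone, it also remains open whether the same methyl would leave inhibition unchanged on a core with other differences, such as that of compound 2.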